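This account rests on a few compounds, and the source may have more. Where it says the series, first, only, none or still open, it means among the compounds named here.

Measured compounds: compound 1 `Oc1cccc(-c2cc(-c3ccc(Cl)cc3)nc(-c3ccsc3)c2)c1`, 11500 nM; compound 2 `Oc1cccc(-c2cc(-c3cccs3)nc(-c3ccccc3Cl)c2)c1`, 3990 nM; compound 3 `Oc1cccc(-c2cc(-c3ccccn3)nc(-c3ccccc3Cl)c2)c1`, "not determined" (no result reported).

In a functional assay on T47D cells (Homo sapiens) for cytotoxicity, read by CCK-8 assay and cell counting, with a stated time of 2 days (a lower number here means a stronger inhibitor, a higher number a weaker inhibitor), compound 3 stands without a number, so it cannot be set beside compound 1 or compound 2 on the scale. Compound 4 `Oc1cccc(-c2cc(-c3ccsc3)nc(-c3ccccc3Cl)c2)c1` differs from compound 3 by thiophen-3-yl in place of pyridin-2-yl on an aromatic carbon. Among the compounds with values here, no measured step covers this change, and no direction can be read for it from the data; the step is expected to be modest, quite possibly within the usual scatter. The two numbers that exist frame the expectation: compound 1 gives 11500 nM in this assay, and compound 2 gives 3990 nM there. Compound 4 is expected to land between these, estimated at 6500 nM, with a range from 2000 nM to 20000 nM.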

Compound 4, half-maximal inhibitory concentration: 2440 nM
The estimate for compound 4 lay 2.7-fold (0.43 log units) above the measured number; low and high end bracket the measured number.
By their numbers in this assay, from the lowest: compounds 4 and 2 (each within the scatter of the next); then compound 1.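

In this assay thiophen-3-yl in place of thiophen-2-yl gives a 1.6-fold lower number from compound 2 to compound 4 (0.21 log units; within the scatter), so the two thiophene attachments are not told apart at this position, while the step from pyridin-2-yl cannot be read, as compound 3 has no number. 2-Chlorophenyl in place of 4-chlorophenyl gives a 4.7-fold lower number from compound 1 to compound 4 (0.67 log units; beyond the scatter), and of these two steps only this one lies beyond the scatter. Nothing given here accounts for either step. The compounds shown leave open how an amine or a carboxylic acid in place of thiophen-3-yl would compare.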